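Dimethylamide to methylpiperazinylpropylamide on a shared core

The compounds below may be only part of what the source reports. "The series", "measured", "known", "first", "only" and "open" are said of these compounds alone.

Among the measured compounds shown here, compound 2 `CCCC1=C(C(=O)OCc2ccc(C(=O)N(C)C)cc2)C(c2cccc(C)c2)NC(=O)N1` is one of two compounds measured in a functional assay on HEK293 cells (Homo sapiens), read by cAMP accumulation; a higher number here means that more compound is needed for the effect, a lower number that less compound is needed. In this assay compound 2 gives 3400 nM, the higher of the two numbers. For the measured compounds named here, its only neighbour is compound 1 `CCCC1=C(C(=O)OCc2ccc(C(=O)NCCCN3CCCCC3)cc2)C(c2cccc(C)c2)NC(=O)N1`, which in this assay gives 1900 nM; the step of a 1.8-fold higher number from compound 1 to compound 2 (0.25 log units; within the scatter) lies within the scatter, so no order can be read between the two. The unmeasured compound 3 `CCCC1=C(C(=O)OCc2ccc(C(=O)NCCCN3CCN(C)CC3)cc2)C(c2cccc(C)c2)NC(=O)N1` differs from compound 2 in one place: (3-(4-methylpiperazin-1-yl)propyl)amino in place of dimethylamino on a carbonyl carbon. Going by the values given here, the one measured step that bears on this change is the one from compound 1 to compound 2, which stayed within the scatter; the group that enters compound 3 resembles the (3-(piperidin-1-yl)propyl)amino of compound 1, with a 4-methylpiperazin-1-yl in place of the piperidin-1-yl. On that basis no step beyond the scatter is expected in this assay, and if anything a somewhat lower number, in line with compound 1 at 1900 nM. Compound 3 is therefore estimated to give 2000 nM, with a range from 800 nM to 5000 nM. The expected step is a 1.7-fold lower number from compound 2 to compound 3 (0.23 log units; within the scatter), within the scatter.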

Compound 3, half-maximal effective concentration: 4300 nM
Estimate against measurement, compound 3: 2.2-fold (0.33 log units) below; the measured number falls inside the stated range.
By their numbers in this assay, from the lowest: compounds 1, 2 and 3 (each within the scatter of the next, the first and the last beyond it).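

In this assay the exchange of dimethylamino for (3-(4-methylpiperazin-1-yl)propyl)amino on the carbonyl carbon gives a 1.3-fold higher number from compound 2 to compound 3 (0.10 log units; within the scatter), so at this place a group of 11 heavy atoms with a six-membered non-aromatic ring, entering for one of 3 heavy atoms with no ring, leaves the number within the scatter. Among the compounds shown here, the new information lies at the far end of the chain, where 4-methylpiperazin-1-yl in place of piperidin-1-yl gives a 2.3-fold higher number from compound 1 to compound 3 (0.35 log units; beyond the scatter), a modest step and the only one among the three compounds that lies beyond the scatter, so in this small set a change in the terminal ring can be read while neither chain-bearing amide can be told apart from the dimethylamide. Nothing available gives a reason for this step.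

The compounds shown leave open whether a morpholine or a dimethylamino group at the end of the same propyl chain would give a number closer to that of compound 1 or to that of compound 3. They also leave open how a shorter ethyl chain or a longer butyl chain to the piperidine would behave in this assay.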